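A few compounds are considered here, and "the series" means these few. Any claim that something is new, unique, unknown or untested is made for them only; others in the source may bear on it.

In an ADME assay on HepG2 cells (Homo sapiens) for cytotoxicity, with a stated time of 72 h (a higher number here means a weaker inhibitor, a lower number a stronger inhibitor), compound 1 (`CCCCc1ccc(-c2ccc(C(=O)N[C@@H](CCCN)C(=O)N[C@H](C(=O)N[C@@H](C)C(=O)N[C@H]3Cc4cn(nn4)CCCN4C[C@@H]5OB(O[C@@H]5C4)[C@H](C)NC3=O)[C@@H](C)O)cc2)cc1`) gives 29100 nM, a measured number. Compound 2 (`C[C@@H]1NC(=O)[C@@H](NC(=O)[C@H](C)NC(=O)[C@@H](NC(=O)[C@H](CCCN)NC(=O)c2ccc(=O)n(-c3ccccc3)c2)[C@@H](C)O)Cc2cn(nn2)CCO[C@@H]2C[C@@H]3OB1O[C@@H]3C2`) gives > 64000 nM, which is a limit of the assay and not a number. Among the compounds with values here, that leaves compound 2 at the limit of > 64000 nM in this assay, at which 1 of the 2 values shown sits, so its true position in this assay is not known, and no single-place step links it to compound 1.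

Compound 3 (`CCCCCCc1ccc(-n2cc(C(=O)N[C@@H](CCCN)C(=O)N[C@H](C(=O)N[C@@H](C)C(=O)N[C@H]3Cc4cn(nn4)CCO[C@@H]4C[C@@H]5OB(O[C@@H]5C4)[C@H](C)NC3=O)[C@@H](C)O)ccc2=O)cc1`) has not yet been measured. It is compound 2 with hexyl in place of hydrogen on an aromatic carbon. Within the data shown here, with no measured step to draw on, the only guide is compound 1, which also carries an alkyl chain and gives a number at 29100 nM. On that thin basis, compound 3 is expected to come off the limit and read as a stronger inhibitor than compound 2, by a step beyond the scatter, though the limit leaves its exact size open. The expected change is an at least 2.5-fold lower number from compound 2 to compound 3 (0.40 log units; beyond the scatter). Compound 3 is estimated at 25000 nM, with an expected range of 10000 nM to 64000 nM.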

Compound 3, half-maximal inhibitory concentration: > 64000 nM
Compound 3 gave a limit, no number; the forecaster's own chance of this, stated with the estimate: 15%; at least 2.5-fold (0.40 log units) between middle value and limit.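

In this assay compound 3 gives > 64000 nM, which is a limit of the assay and not a number. Compound 2 also stands at a limit, so no step can be read between compound 2 and compound 3. The compounds shown leave open whether hexyl in place of hydrogen on an aromatic carbon changes the true value at all.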